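From 3-cyanophenyl to 4-vinylphenyl on a shared core

The source may hold more compounds than are shown below. What is called first, only, known or untested is meant among the compounds shown, and "the series" means these compounds.

In a functional assay on A549 cells (Homo sapiens) for inhibition, read by CCK-8 assay, with a stated time of 48 h (a higher number here means a weaker inhibitor, a lower number a stronger inhibitor), compound 1 (`COc1cc(-c2cc3nccc(-c4cc(OC)c(OC)c(OC)c4)n3n2)cc(OC)c1OC`) gives > 10000 nM as its result, a limit of the assay and not a number. Compound 2 (`COc1cc(-c2ccnc3cc(-c4cccc(C#N)c4)nn23)cc(OC)c1OC`) gives > 10000 nM as its result, again only a limit. Compound 3 (`C=Cc1ccc(-c2cc3nccc(-c4cc(OC)c(OC)c(OC)c4)n3n2)cc1`) carries 4-vinylphenyl in place of 3-cyanophenyl on an aromatic carbon. Going by the values given here, no measured pair shows what such a swap does, so only a modest move towards stronger inhibition is expected, and compound 3 may also end at the limit. The expected change is an at least 2.0-fold lower number from compound 2 to compound 3 (0.30 log units; that floor lies within the scatter) in size. For compound 3 the estimated value is 5000 nM in a range from 400 nM to 20000 nM as expected here.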

Compound 3, half-maximal inhibitory concentration: 1030 nM
For compound 3 the middle estimate is 4.9-fold (0.69 log units) above the measured one; the measured number falls inside the stated range.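

Compound 3 is the only one of the three with a real number, which shows that a compound with this group at this position on the shared core can register in this assay. Compound 2 gives > 10000 nM, a limit of the assay and not a number. Going by these compounds, exchanging 3-cyanophenyl for 4-vinylphenyl produces an at least 9.7-fold lower number from compound 2 to compound 3 (0.98 log units; beyond the scatter), so the full size of the step stays unknown.

This exchange alters both the group and where it sits on the phenyl ring, so the two contributions cannot be separated. Neither 4-cyanophenyl nor 4-ethylphenyl is among the compounds shown, and either would help to tell them apart.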